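Chloromethylbenzyl purines: cytotoxicity of a two-chlorine core

A few compounds are considered here, and "the series" means these few. Any claim that something is new, unique, unknown or untested is made for them only; others in the source may bear on it.

Compound 1 `ClCc1ccccc1Cn1cnc2c(Cl)nc(Cl)nc21` — 470 nM
Compound 2 `ClCc1cccc(Cn2cnc3c(Cl)ncnc32)c1` — 7620 nM
Compound 3 `ClCc1ccc(Cn2cnc3c(Cl)nc(Cl)nc32)cc1` — 14100 nM

In a functional assay on CCRF-CEM cells (Homo sapiens) for cytotoxicity, read by sulforhodamine B assay, with a stated time of 48 h (a lower number here means that less compound is tolerated, a higher number that more compound is tolerated), compound 1 gives 470 nM, the lowest of the three numbers; compound 2 gives 7620 nM and compound 3 gives 14100 nM, both well beyond the scatter. Among the compounds with values here, the three also differ in where the chloromethyl group sits and in the second chlorine on the core, so no single step between them can be read off.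

Compound 4 `Nc1nc(Cl)c2ncn(Cc3ccccc3CCl)c2n1` keeps everything of compound 1 except one change: amino in place of chloro on an aromatic carbon, on the carbon between two ring nitrogen atoms. Within the data shown here, no measured pair isolates this exchange. The step from compound 1 to compound 4 is expected to be a 3.2-fold higher number from compound 1 to compound 4 (0.50 log units; beyond the scatter), a moderate rise. Compound 4 is therefore estimated at 1500 nM, within 300 nM to 8000 nM.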

Compound 4, concentration lethal to 50% of the cells: > 100000 nM
Compound 4: no number, only a limit; the forecaster's own chance of this, stated with the estimate: 5%; middle value at least 66-fold (1.82 log units) away from the limit.
By their numbers in this assay, from the lowest: compound 1; then compounds 2 and 3 (each within the scatter of the next). At a limit, above all of these: compound 4.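

Within the data shown here, on the carbon between two ring nitrogen atoms, amino in place of chloro gives an at least 210-fold higher number from compound 1 to compound 4 (2.32 log units; beyond the scatter) in this assay, the first step at this position that can be read from a single change. Far more of compound 4 is tolerated than of compound 1, so the chloro there cannot be exchanged for amino without a large rise. The result for compound 4 is a limit of the assay and not a number: the limit of > 100000 nM in this assay, at which 1 of the 4 values shown sits.

From the compounds shown here alone, it remains open how a methylamino or methoxy group on this carbon would read. Going by these compounds, whether the same exchange would have a similar effect on compound 3 also remains open.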